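A Benzyl-to-Aryl Amide Change on a Chromone Scaffold

The compounds below may be only part of what the source reports. "The series", "measured", "known", "first", "only" and "open" are said of these compounds alone.

In a functional assay on Huh-7 cells (Homo sapiens) for inhibition, read by MTT assay, with a stated time of 48 h (on this read-out lower numbers stand for stronger inhibition and higher numbers for weaker inhibition), compound 2 `COc1ccc2c(=O)c(/C=C/C(=O)NCc3ccccc3F)coc2c1` gives 8450 nM. Compound 1 `COc1ccc2c(=O)c(/C=C/C(=O)NCc3cccc(F)c3)coc2c1` gives 10100 nM, and the step of a 1.2-fold lower number from compound 1 to compound 2 (0.08 log units; within the scatter) lies within the scatter, so the two stand level on this assay. Compound 3 `COc1ccc2c(=O)c(/C=C/C(=O)Nc3ccccc3OC)coc2c1` differs from compound 2 by 2-methoxyphenyl in place of 2-fluorobenzyl on an amide-type nitrogen. Among the compounds with values here, no measured step touches the amide nitrogen in this way, and the one step on record moved only a fluorine around its ring, so no direction can be drawn from it. The expected step of a 1.1-fold lower number from compound 2 to compound 3 (0.02 log units; within the scatter) is therefore estimated as none beyond the scatter, and compound 3 is expected at 8000 nM, within 2500 nM to 25000 nM.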

Compound 3, half-maximal inhibitory concentration: 32300 nM
Estimate against measurement, compound 3: 4.0-fold (0.61 log units) below, and the stated range ends below it.
By their numbers in this assay, from the lowest: compounds 2 and 1 (each within the scatter of the next); then compound 3.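

The amide-type nitrogen responds to what it carries, which the fluorine move between the two benzyl compounds could not show. In this assay, replacing either fluorobenzyl group with 2-methoxyphenyl weakens inhibition beyond the scatter (a 3.8-fold higher number from compound 2 to compound 3 (0.58 log units; beyond the scatter)) (a 3.2-fold higher number from compound 1 to compound 3 (0.50 log units; beyond the scatter)). Nothing measured here explains this loss.

This change alters both the link to the ring and the ring's substituent, and the compounds shown do not separate the two. A 2-methoxybenzyl or 2-fluorophenyl group on the same nitrogen would tell them apart.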